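The source may report more compounds than this note shows. Statements on the series, on what has been measured and on what is new or still open speak of the compounds shown alone.

Working notes on the series in a functional assay on HeLa cells (Homo sapiens) for cytotoxicity, read by WST assay, with a stated time of 48 h; a lower number here means a stronger inhibitor, a higher number a weaker inhibitor.

Of the compounds shown here, three carry numbers so far. Compound 1 `COc1cccc([C@H]2OC[C@H]([C@@H](O)c3ccc(OC)c(OC)c3)C[C@@H]2C/C=C/c2ccc(OC)c(OC)c2)c1` gives 21800 nM in this assay. Compound 2 `COc1ccc([C@H]2OC[C@H]([C@@H](O)c3ccc(OC)c(OC)c3)C[C@@H]2C/C=C/c2ccccc2)cc1OC` gives 14800 nM in this assay, which sits within the usual scatter of the value of compound 1. Compound 3 `COc1ccc(/C=C/C[C@H]2C[C@@H]([C@@H](OC(C)=O)c3ccc(OC)c(OC)c3)CO[C@@H]2c2ccc(OC)c(OC)c2)cc1OC` is recorded only as > 100000 nM in this assay, and that is a limit of the assay rather than a number; it stands at the limit of > 100000 nM in this assay, at which 1 of the 3 values shown sits. No pair among these three differs in one place only, so no single measured step is counted here.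

The step under consideration goes from compound 3 to compound 4 `COc1ccc(/C=C/C[C@H]2C[C@@H]([C@@H](O)c3ccc(OC)c(OC)c3)CO[C@@H]2c2ccc(OC)c(OC)c2)cc1OC`. The change is hydrogen in place of acetyl on an oxygen on a saturated carbon, that is, acetoxy to hydroxy when the cut is taken one bond further out. Compound 4 thus carries the same hydroxy group that compound 1 and compound 2 carry, and both of those sit well inside the measurable range of this assay. On that basis the step is expected to move downward, toward a measurable number, rather than to stay at the limit. The step from compound 3 to compound 4 is estimated as an at least 4.0-fold lower number from compound 3 to compound 4 (0.60 log units; beyond the scatter). For compound 4 the expected value in this assay is 25000 nM, with a range from 8000 nM to 90000 nM.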

Compound 4, half-maximal inhibitory concentration: 23800 nM
Estimate against measurement, compound 4: 1.1-fold (0.02 log units) above; low and high end bracket the measured number.
By their numbers in this assay, from the lowest: compounds 2, 1 and 4 (each within the scatter of the next). At a limit, above all of these: compound 3.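

In this assay, among these compounds, hydrogen in place of acetyl on an oxygen on a saturated carbon gives the only single-place step at this position, an at least 4.2-fold lower number from compound 3 to compound 4 (0.62 log units; beyond the scatter) and so ties the measurable number of compound 4 to the free hydroxy rather than the acetoxy form of the same structure. Compound 3 is recorded only at a limit of the assay, so the step has a lower bound and no exact size: the limit of > 100000 nM in this assay, at which 1 of the 4 values shown sits.

With the hydroxy in place, the two changes elsewhere on the molecule stay within the scatter, with 3,4-dimethoxyphenyl in place of phenyl on a double-bonded chain carbon bound to a double-bonded chain carbon giving a 1.6-fold higher number from compound 2 to compound 4 (0.21 log units; within the scatter) and methoxy in place of hydrogen on an aromatic carbon giving a 1.1-fold higher number from compound 1 to compound 4 (0.04 log units; within the scatter) in this series.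

Among the compounds shown here, the single acetoxy to hydroxy pair leaves open whether the limit of compound 3 is particular to acetyl or would also appear with a longer acyl chain such as butyryl on that oxygen. As far as these compounds go, whether an amine in place of the hydroxy would keep a measurable number also remains open.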